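The source may report more compounds than this note shows. Statements on the series, on what has been measured and on what is new or still open speak of the compounds shown alone.

Going by the values given here, compound 2 `COc1cc(=O)n(C)cc1-c1ccnc2[nH]c(C3CCN(CC(=O)N(C)C)CC3)cc12` stands lowest of the two numbers measured so far in a physicochemical assay for lipophilicity, using the shake flask method, measured as octanol-water partition, at pH 7.4; a lower number here means a more polar compound, a higher number a more lipophilic compound: compound 2 gives 0.7, while compound 1 `CC(C)n1nc(-c2ccnc3[nH]c(C4CCN(CC(=O)N(C)C)CC4)cc23)ccc1=O` gives 2. Among the compounds with values here, the single measured step, a number 1.30 log units lower from compound 1 to compound 2 (beyond the scatter), exchanges one ring for another and is large. Compound 3 `CN(C)C(=O)CN1CCC(c2cc3c(-c4ccc(=O)n(C)c4)ccnc3[nH]2)CC1` differs from compound 2 in a smaller way: hydrogen in place of methoxy on an aromatic carbon. Within the data shown here, no measured step here covers the loss of a methoxy group, so the one known step, a ring exchange, gives no direct guide, and the change itself is small in what is counted. A step in this assay that stays within the usual scatter is therefore expected, with no clear direction. The estimate for compound 3 is 0.7, from 0.3 to 1.1, which means an expected step of no change at the digits printed from compound 2 to compound 3 (within the scatter).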

Compound 3, distribution coefficient: 1.1
Compound 3: the middle estimate sits 0.40 log units below what was measured, and the stated range covers the measured number.
By their numbers in this assay, from the lowest: compound 2; then compound 3; then compound 1.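

In this assay, hydrogen in place of methoxy on the aromatic carbon opposite the ring nitrogen gives a number 0.40 log units higher from compound 2 to compound 3 (beyond the scatter), so this one small group on the ring has a measurable effect on the number. The new compound also divides the earlier large step, a number 1.30 log units lower from compound 1 to compound 2 (beyond the scatter), into two parts. Without the methoxy group, the exchange of the ring group alone still gives a number 0.90 log units lower from compound 1 to compound 3 (beyond the scatter), and this is the larger part of the earlier step.

Nothing available explains why removing the methoxy group raises the number. Going by these compounds, it remains open whether an ethoxy group, a fluorine atom or an amine on this same carbon would shift the number further, and whether the methoxy step would be of similar size on the ring of compound 1.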